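Phenyl for Methyl on the Ring Nitrogen

This account rests on a few compounds, and the source may have more. Where it says the series, first, only, none or still open, it means among the compounds named here.

Of the compounds shown here, three have been measured in an assay on isolated protein for inhibition of Fatty-acid amide hydrolase 1 (Homo sapiens), read by fluorescence, with a stated time of 30 min (a lower number here means a stronger inhibitor, a higher number a weaker inhibitor), so far. Compound 1 `CCOC(=O)c1cc(-c2cccc(OC(=O)NC3CCCCC3)c2)n(-c2ccc(C)cc2)n1` gives 29 nM in this assay. Compound 2 `Cn1nc(C(N)=O)cc1-c1ccc(OC(=O)NC2CCCCC2)cc1` gives 209 nM. Compound 3 `CCOC(=O)c1cc(-c2ccc(OC(=O)NC3CCCCC3)cc2)nn1C` gives 316 nM, the highest of the three numbers, although its value and that of compound 2 lie within the scatter of each other, so no order between those two can be read. Compound 1, by contrast, sits well below compound 3, beyond the scatter; compound 1 differs from compound 3 in more than one place, so its lower number cannot be tied to a single change.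

Compound 4 `CCOC(=O)c1cc(-c2ccc(OC(=O)NC3CCCCC3)cc2)nn1-c1ccccc1` is not yet measured. It differs from compound 3 by phenyl in place of methyl on an aromatic nitrogen. Compound 1 also carries a substituted phenyl rather than a methyl on an aromatic nitrogen and gives the lowest number of the set, which is the only hint available for the direction of this step. On that basis compound 4 is expected to give a lower number than compound 3 in this assay, with a step of roughly a 4.5-fold lower number from compound 3 to compound 4 (0.65 log units; beyond the scatter). The estimate for compound 4 in this assay is 70 nM, with a plausible range from 15 nM to 300 nM.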

Compound 4, half-maximal inhibitory concentration: 592 nM
Compound 4: the middle estimate sits 8.5-fold (0.93 log units) below what was measured; measured number outside the range, above it.
By their numbers in this assay, from the lowest: compound 1; then compounds 2, 3 and 4 (each within the scatter of the next, the first and the last beyond it).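

In this assay, phenyl in place of methyl on the aromatic nitrogen gives a 1.9-fold higher number from compound 3 to compound 4 (0.27 log units; within the scatter) and so leaves the two compounds unseparated, even though 6 heavy atoms replace 1 at this position, next to the ring atom that bears an ethoxycarbonyl group. A phenyl on this nitrogen thus brings no gain that can be read from this pair, and the value of compound 1 at 29 nM remains untied to any single change. Nothing measured here offers an explanation for this step.

The compounds shown leave open whether any group on this nitrogen can move the number beyond the scatter, since a hydrogen, a benzyl group or a longer alkyl chain does not appear there among them. They also leave open whether the exchange of methyl for phenyl would read the same in a compound that carries a carboxylic acid in place of the ethoxycarbonyl group, or in one with the carbamate placed as in compound 1.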